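This account rests on a few compounds, and the source may have more. Where it says the series, first, only, none or still open, it means among the compounds named here.

Compound 2 `COc1cc(/C=C/c2nc(Nc3ccc(C(F)(F)F)cc3)c3sccc3n2)cc(OC)c1OC` — 436000 nM
Compound 1 `CC(C)CNc1nc(/C=C/c2ccccc2)nc2ccsc12` — > 1000000 nM (a limit of the assay)

Of the compounds shown here, two with the shared core have been tested in a functional assay on L02 cells (Homo sapiens) for inhibition, read by Griess assay, with stated times of 1 h and 24 h; a lower number here means a stronger inhibitor, a higher number a weaker inhibitor. Within the data shown here, compound 2 gives 436000 nM, the only actual number in the set. For compound 1 the value > 1000000 nM is a limit of the assay rather than a number. Compound 1 thus sits at the limit of > 1000000 nM in this assay, at which 1 of the 2 values shown sits, and compound 2 stands alone as the single measured point.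

Compound 3 `COc1cc(/C=C/c2nc(NCc3ccco3)c3sccc3n2)cc(OC)c1OC` has not yet been measured. It differs from compound 2 by (furan-2-yl)methyl in place of 4-(trifluoromethyl)phenyl on a nitrogen on an aromatic ring. Among the measured compounds shown here, no step between measured compounds is available, so there is no precedent here for the size of this change. Compound 3 is expected to be slightly weaker, a step of a 1.5-fold higher number from compound 2 to compound 3 (0.17 log units; within the scatter) that may not exceed the scatter. The estimate for compound 3 in this assay is 650000 nM, with a range from 200000 nM to 2000000 nM.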

Compound 3, half-maximal inhibitory concentration: 189000 nM
Beside the measured number, compound 3's estimate is 3.4-fold (0.54 log units) above it; measured number below the stated range.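

In this assay, the substituent on a nitrogen on an aromatic ring now has its first measured step: (furan-2-yl)methyl in place of 4-(trifluoromethyl)phenyl gives a 2.3-fold lower number from compound 2 to compound 3 (0.36 log units; beyond the scatter). Among these compounds, the earlier compounds offered no such pair, so this is the first sign that the number responds to a change at this position, although compound 3 still reads 189000 nM, a large number on this scale. Nothing measured here accounts for the size of the step.

This single step replaces the aromatic ring and its trifluoromethyl group and also adds a methyl link, so the compounds shown do not separate these changes. Open too, as far as these compounds go, is how the number would move with a benzyl group, which would keep the carbon-only six-membered ring on the same link, or with an unsubstituted furan-2-yl ring.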